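Changing One Aryl Substituent: Expected Cytotoxicity of Compound 4

A few compounds are considered here, and "the series" means these few. Any claim that something is new, unique, unknown or untested is made for them only; others in the source may bear on it.

Three compounds have been measured in an ADME assay on PC-3 cells (Homo sapiens) for cytotoxicity, read by WST assay, tested at 100 uM; a higher number here means more inhibition at the concentration tested (going by the name of the read-out), a lower number less inhibition:
Compound 1 `Cc1cccc(C(=O)N2CCCC(C(=O)Nc3ccc(Cl)cc3)C2)c1` gives 0%.
Compound 2 `Cc1nc(-c2cccc(NC(=O)C3CCCN(C(=O)c4cc(C(F)(F)F)cc(C(F)(F)F)c4)C3)c2)cs1` gives 1%.
Compound 3 `O=C(Nc1ccc(Cl)cc1)C1CCCN(C(=O)c2cccc(-c3cccs3)c2)C1` gives 4%.

All three numbers lie within the scatter of one another, so compound 2 cannot be called higher or lower than its neighbours. Going by the values given here, the only single-point step measured, a number 4 percentage points higher from compound 1 to compound 3 (within the scatter), exchanges one group on an aromatic carbon and leaves the read-out essentially unchanged. Compound 4 `CC(C)(C)OC(=O)c1cccc(NC(=O)C2CCCN(C(=O)c3cc(C(F)(F)F)cc(C(F)(F)F)c3)C2)c1` differs from compound 2 by tert-butoxycarbonyl in place of 2-methyl-1,3-thiazol-4-yl on an aromatic carbon. Among the compounds with values here, that change has no direct precedent here, but every measured compound sits near zero, and the one measured step stayed within the scatter, so no step beyond the scatter is expected: a number 1 percentage points higher from compound 2 to compound 4 (within the scatter). Compound 4 is therefore estimated at 2%, with a range from 0% to 12%.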

Compound 4, a percentage reported as inhibition, at one concentration (the size of the read-out at that concentration, not a potency): 0%
Compound 4: middle estimate off by 2 percentage points, on the high side; the measured number falls inside the stated range.
By their numbers in this assay, from the lowest: compounds 1, 4, 2 and 3 (each within the scatter of the next).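

With tert-butoxycarbonyl replacing 2-methyl-1,3-thiazol-4-yl in this assay, the result is a number 1 percentage points lower from compound 2 to compound 4 (within the scatter). This position, meta to a large group, therefore accepts a group with no ring in place of a five-membered aromatic ring without a step beyond the usual scatter, which compound 2 alone could not show. Nothing available explains this result. Going by these compounds, whether an amine or a carboxylic acid at this position would give a clear step remains open. So does whether any group here can raise the read-out beyond the scatter.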